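Swapping the sulfonyl for a ketone on the chain

The source may report more compounds than this note shows. Statements on the series, on what has been measured and on what is new or still open speak of the compounds shown alone.

Of the compounds shown here, three that share one core have been measured in a functional assay on UO-31 cells (Homo sapiens) for inhibition, read by sulforhodamine B assay, with a stated time of 48 h; on this read-out higher numbers stand for weaker inhibition of growth and lower numbers for stronger inhibition of growth. Compound 1 `CC(=O)/C(=C\c1c(-c2ccccc2)[nH]c2ccccc12)S(=O)(=O)c1ccccc1` gives 1600 nM, compound 2 `COc1ccc2[nH]c(-c3ccccc3)c(/C=C(\C#N)S(=O)(=O)c3ccccc3)c2c1` gives 4000 nM, and compound 3 `N#C/C(=C\c1c(-c2ccccc2)[nH]c2ccccc12)S(=O)(=O)c1ccccc1` gives 6700 nM. Compound 3 thus carries the highest number of the three: the gap to compound 2 lies within the scatter, while the step of a 4.2-fold higher number from compound 1 to compound 3 (0.62 log units; beyond the scatter) lies beyond it, so compound 3 is a weaker growth inhibitor than compound 1.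

Compound 4 `N#C/C(=C\c1c(-c2ccccc2)[nH]c2ccccc12)C(=O)c1ccccc1` is the next step from compound 3. The change is benzoyl in place of phenylsulfonyl on a double-bonded chain carbon bound to a double-bonded chain carbon and a triple-bonded carbon. Neither measured step tests this particular swap. The step of a 4.2-fold higher number from compound 1 to compound 3 (0.62 log units; beyond the scatter) concerns the other group on the same chain carbon, cyano against acetyl, and says nothing about the phenylsulfonyl itself; the step of a 1.7-fold higher number from compound 2 to compound 3 (0.22 log units; within the scatter) concerns a methoxy on the core and is within the scatter. There is therefore no measured guide to the direction of the new step in this assay, and a number close to that of compound 3, with room for a modest move either way, is the most that can be expected.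

The estimate for compound 4 is therefore 5000 nM, in the range 1500 nM to 16000 nM, which means an expected step of a 1.3-fold lower number from compound 3 to compound 4 (0.13 log units; within the scatter).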

Compound 4, concentration for 50% growth inhibition: 30500 nM
The estimate for compound 4 lay 6.1-fold (0.79 log units) below the measured number, and the stated range ends below it.
By their numbers in this assay, from the lowest: compound 1; then compounds 2 and 3 (each within the scatter of the next); then compound 4.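

Going by these compounds alone, this is the first measured test of the phenylsulfonyl on this chain carbon, and in this assay benzoyl does not serve as an equal replacement: the swap gives a 4.6-fold higher number from compound 3 to compound 4 (0.66 log units; beyond the scatter), so growth inhibition is weaker with benzoyl. Both groups carry a six-membered aromatic ring of carbon only, so the change lies in the sulfonyl link giving way to a carbonyl, and the ring alone does not preserve the effect; together with a 4.2-fold higher number from compound 1 to compound 3 (0.62 log units; beyond the scatter), this shows that changes to either group on the chain's substituted carbon can move the number beyond the scatter. No measurement available here explains why this swap has this effect.

The compounds shown leave open whether the same swap would cost as much with acetyl in place of cyano, or with methoxy on the core. As far as these compounds go, they also do not show how a carboxylic acid, an amide or a methylsulfonyl group would behave in place of the phenylsulfonyl, so the range of groups tolerated on this chain carbon remains unknown.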